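Methylating the Phenol of Compound 1

The compounds below may be only part of what the source reports. "The series", "measured", "known", "first", "only" and "open" are said of these compounds alone.

Compound 1 `O=C1/C(=C/c2ccc(O)cc2)Cc2ccccc2/C1=C\c1ccc([N+](=O)[O-])cc1` shows the lower of the two numbers recorded so far in a functional assay on HPLF cells (Homo sapiens) for cytotoxicity (on this read-out higher numbers stand for lower toxicity in this test and lower numbers for higher toxicity in this test), giving 75000 nM. Compound 2 `COc1ccc(/C=C2\CCC/C(=C\c3ccc([N+](=O)[O-])cc3)C2=O)cc1OC` gives 95000 nM in this assay, and the gap between the two values lies within the scatter. Compound 3 `COc1ccc(/C=C2\Cc3ccccc3/C(=C\c3ccc([N+](=O)[O-])cc3)C2=O)cc1` has not yet been measured. It differs from compound 1 in one place: methyl in place of hydrogen on an oxygen on an aromatic ring. Going by the values given here, no step between measured compounds is known here, so the step of a 1.1-fold higher number from compound 1 to compound 3 (0.03 log units; within the scatter) is expected to be none beyond the scatter. Compound 3 is therefore estimated to give 80000 nM, with a range from 40000 nM to 160000 nM.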

Compound 3, half-maximal cytotoxic concentration: > 400000 nM
Compound 3 gave a limit, no number (the forecaster's own chance of this, stated with the estimate: 10%); at least 5.0-fold (0.69 log units) between middle value and limit.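

Going from hydroxy to methoxy on the aromatic ring gives a clear step in this assay, with an at least 5.3-fold higher number from compound 1 to compound 3 (0.72 log units; beyond the scatter). The earlier pair, compound 1 and compound 2, differ in more than one place and could not show that this single oxygen responds to an added methyl. The entry for compound 3 is a limit and not a number, so the full size of the step stays unknown: the limit of > 400000 nM in this assay, at which 1 of the 3 values shown sits.

On these data alone, whether any group on this oxygen would do the same remains open. An ethyl or longer chain there, or an amine in place of the hydroxy, is not among the compounds shown.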